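From benzofuranyl to iodo on a shared core

This account rests on a few compounds, and the source may have more. Where it says the series, first, only, none or still open, it means among the compounds named here.

The study follows growth inhibition in an ADME assay on BJ cells (Homo sapiens), read by MTT assay, with a stated time of 72 h; a higher number here means a weaker inhibitor, a lower number a stronger inhibitor. Compound 1 `Nc1nc(N)c2c(-c3cc4ccccc4o3)cn([C@@H]3O[C@H](CO)[C@@H](O)[C@H]3O)c2n1` is one anchor. In this assay compound 1 gives only a limit of the assay, > 100000 nM. Compound 2 `CNc1ncnc2c1c(-c1ccccc1)cn2[C@@H]1O[C@H](CO)[C@@H](O)[C@H]1O` likewise returns only a limit in this assay, > 100000 nM. Compound 3 `Cc1nc(N)c2c(-c3cc4ccccc4o3)cn([C@@H]3O[C@H](CO)[C@@H](O)[C@H]3O)c2n1` also sits at a limit in this assay, > 100000 nM. The step that the two limits leave unreadable from compound 1 to compound 3 cannot be read, since the limit of > 100000 nM in this assay, at which 3 of the 3 values shown sit, marks where all three values stand. Compound 4 `Cc1nc(N)c2c(I)cn([C@@H]3O[C@H](CO)[C@@H](O)[C@H]3O)c2n1` differs from compound 3 by iodo in place of 1-benzofuran-2-yl on an aromatic carbon. For the measured compounds named here, no measured pair bears on this change, and the single step that is shown sits at another place and is itself unreadable. For compound 4 the expected step that the limit leaves unreadable from compound 3 to compound 4 therefore has no direction that can be read beyond the scatter, and the value is expected to remain at or near the limit. Compound 4 is estimated at 150000 nM, within 50000 nM to 500000 nM, with another limit the most likely outcome.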

Compound 4, half-maximal inhibitory concentration: 24600 nM
Compound 4: the middle estimate sits 6.1-fold (0.79 log units) above what was measured; measured number below the stated range.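

In this assay, for the compounds shown here, iodo in place of 1-benzofuran-2-yl on this aromatic carbon gives an at least 4.0-fold lower number from compound 3 to compound 4 (0.60 log units; beyond the scatter) and is the only step in the set that can be read. Going by these compounds alone, it shows that a change at this position can bring a compound on the shared core off the limit, something the earlier compounds did not show. Compound 4 alone carries a number, and the step from compound 1 to compound 3 cannot be read, since the other compounds give only a limit: the limit of > 100000 nM in this assay, at which 3 of the 4 values shown sit.

From the compounds shown here alone, the true size of the step stays open, as does whether the gain belongs to iodo itself or to the loss of the 1-benzofuran-2-yl group. Nor do the compounds shown tell how a bromo, a chloro or an amine at this carbon would read, or whether amino in place of methyl would matter alongside iodo.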